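Trifluoromethyl for Trifluoromethoxy: Cytotoxicity Stays at the Limit

The compounds below may be only part of what the source reports. "The series", "measured", "known", "first", "only" and "open" are said of these compounds alone.

compound 1 `CCOC(=O)c1c(-c2cccc(OC(F)(F)F)c2)[nH]c2cc(OC)ccc2c1=O` — > 21500 nM, a limit of the assay
compound 2 `CCOC(=O)c1c(-c2cccc(C(F)(F)F)c2)[nH]c2cc(OC)ccc2c1=O` — > 21500 nM, a limit of the assay
compound 3 `CCOC(=O)c1c(-c2cccc(OC)c2)[nH]c2cc(OC(F)(F)F)ccc2c1=O` — > 21500 nM, a limit of the assay

Among the compounds with values here, in an ADME assay on HepG2 cells (Homo sapiens) for cytotoxicity, read by luminescence, with a stated time of 72 h (on this read-out higher numbers stand for an effect only at larger amounts of compound and lower numbers for an effect already at smaller amounts), every value so far is a limit rather than a number, as the limit of > 21500 nM in this assay, at which 3 of the 3 values shown sit, states. From compound 1 to compound 2 the change is trifluoromethyl in place of trifluoromethoxy on an aromatic carbon, and the step is a step that the two limits leave unreadable from compound 1 to compound 2. The difference between the cores of compound 1 and compound 3 is not broken down here. Compound 4 `CCOC(=O)c1c(-c2cccc(OC)c2)[nH]c2cc(C(F)(F)F)ccc2c1=O` is not yet measured; it differs from compound 3 by trifluoromethyl in place of trifluoromethoxy on an aromatic carbon, the same kind of change as before, though the place differs: on an aromatic carbon of a six-membered aromatic ring of carbon only, part of a fused or bridged system of two rings, meta to a fused ring and para to a fused ring, rather than meta to a large group. Because compound 3 sits at > 21500 nM, the step that the limit leaves unreadable from compound 3 to compound 4 is expected to stay unreadable. Compound 4 is estimated at 30000 nM in this assay.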

Compound 4, half-maximal effective concentration: > 21500 nM
Compound 4 ended at the assay's limit; the forecaster's own chance of this, stated with the estimate: 85%; the middle value does not contradict the limit.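

No step can be read from compound 3 to compound 4, because both values are limits of the assay rather than numbers: the limit of > 21500 nM in this assay, at which 4 of the 4 values shown sit.

The compounds shown leave open whether trifluoromethyl and trifluoromethoxy differ at all in this assay, and at what concentration, if any, these four compounds would show an effect.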